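This account rests on a few compounds, and the source may have more. Where it says the series, first, only, none or still open, it means among the compounds named here.

Compound 1 `COc1ccc(-c2c(S(=O)(=O)c3ccc(F)c(F)c3)cnc3cc(F)ccc23)cc1`: 1.1 mL/min
Compound 2 `COc1ccc(-c2c(S(=O)(=O)c3cc(F)cc(F)c3)cnc3cc(F)ccc23)cc1`: 1.51 mL/min
Compound 3 `COc1ccc(-c2c(S(=O)(=O)c3cc(Cl)cc(Cl)c3)cnc3cc(F)ccc23)cc1`: 1 mL/min

These three compounds have been tested in an ADME assay on microsomes from liver (Homo sapiens) for metabolic stability, tested at 2.5 uM; on this read-out higher numbers stand for fast clearance and lower numbers for slow clearance. Compound 1 gives the second highest of the three numbers; its nearest neighbour is compound 3, a 1.1-fold lower number from compound 1 to compound 3 (0.04 log units; within the scatter), and the furthest is compound 2, a 1.4-fold higher number from compound 1 to compound 2 (0.14 log units; within the scatter), so all three sit within the scatter of one another. Compound 4 `O=S(=O)(c1ccc(F)c(F)c1)c1cnc2cc(F)ccc2c1-c1ccccc1F` has not been measured. It differs from compound 1 in one place: 2-fluorophenyl in place of 4-methoxyphenyl on an aromatic carbon. Every measured step changes the group on the sulfonyl sulfur; none touches the change from compound 1 to compound 4, and nothing in the data supports a step beyond the scatter in this assay. Compound 4 is thus estimated at 1 mL/min, in the range 0.5 mL/min to 2.2 mL/min, meaning an expected step of a 1.1-fold lower number from compound 1 to compound 4 (0.04 log units; within the scatter).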

Compound 4, intrinsic clearance in a liver preparation (reported as CLH), per the amount of preparation that the assay uses: 0.79 mL/min
Compound 4: middle estimate off by 1.3-fold (0.10 log units), on the high side; the range from low to high includes it.
By their numbers in this assay, from the lowest: compounds 4, 3, 1 and 2 (each within the scatter of the next).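

In this assay, 2-fluorophenyl in place of 4-methoxyphenyl on this aromatic carbon gives a 1.4-fold lower number from compound 1 to compound 4 (0.14 log units; within the scatter). Within the data shown here, this is the first measured change away from the sulfonyl sulfur, and it shows that this swap of one substituted phenyl ring for another, which also removes a hydrogen-bond acceptor, stays within the scatter. No measurement here offers an explanation for this result. The compounds shown leave open whether a group other than a phenyl ring at this position, such as an amine or a carboxylic acid, would give a step beyond the scatter.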